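Swapping the amide group of compound 3

The source may report more compounds than this note shows. Statements on the series, on what has been measured and on what is new or still open speak of the compounds shown alone.

In a functional assay on U-937 cells (Homo sapiens) for antiproliferative activity, read by MTT assay, with a stated time of 72 h (on this read-out higher numbers stand for weaker inhibition and lower numbers for stronger inhibition), compound 1 (`Nc1ccccc1NC(=O)CCCCCCc1nc(-c2ccc(C(F)(F)F)cc2)no1`) gives 5280 nM, compound 2 (`Nc1ccccc1NC(=O)CCCCCCc1nc(-c2ccccc2Cl)no1`) gives 6910 nM and compound 3 (`Nc1ccccc1NC(=O)CCCCCCc1nc(-c2ccc([N+](=O)[O-])cc2)no1`) gives 10300 nM. Compound 3 stands level with the other two: a 2.0-fold higher number from compound 1 to compound 3 (0.29 log units; within the scatter) and a 1.5-fold higher number from compound 2 to compound 3 (0.17 log units; within the scatter), and a 1.3-fold higher number from compound 1 to compound 2 (0.12 log units; within the scatter) is no larger in meaning. Compound 4 (`O=C(CCCCCCc1nc(-c2ccc([N+](=O)[O-])cc2)no1)C(F)(F)F`) differs from compound 3 by trifluoromethyl in place of (2-aminophenyl)amino on a carbonyl carbon. Among the compounds with values here, the three measured steps only exchange aromatic groups, so none tests this change directly, and the data hold no step at this place. A modest move toward weaker inhibition in this assay is therefore only a tentative expectation, an estimated 1.7-fold higher number from compound 3 to compound 4 (0.24 log units; within the scatter). For compound 4 the estimated value is 18000 nM, with an expected range of 5000 nM to 60000 nM.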

Compound 4, half-maximal inhibitory concentration: 3680 nM
Compound 4: middle estimate off by 4.9-fold (0.69 log units), on the high side; measured number below the stated range.
By their numbers in this assay, from the lowest: compounds 4, 1, 2 and 3 (each within the scatter of the next, the first and the last beyond it).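

Within the data shown here, at this carbonyl carbon, the change gives a 2.8-fold lower number from compound 3 to compound 4 (0.45 log units; beyond the scatter) in this assay, the only step that lies beyond the scatter; the aromatic exchanges all stayed within it. Activity in this assay therefore does not depend on the (2-aminophenyl)amino group, since trifluoromethyl, with no ring and no hydrogen-bond donors, serves at least as well here. No measurement shown explains why the number falls. As far as these compounds go, it remains open how a carboxylic acid or a hydroxamic acid would behave on the same carbonyl carbon, and whether trifluoromethyl gives a similar step with the 2-chlorophenyl or 4-(trifluoromethyl)phenyl group in place of 4-nitrophenyl.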